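The compounds below may be only part of what the source reports. "The series", "measured", "known", "first", "only" and "open" are said of these compounds alone.

Measured so far:
compound 1 `COc1cc(NC(=O)c2ccc(F)cc2)cc(OC)c1OC` — >= 125000 nM
compound 2 `COc1cc(NC(=O)c2cccc([N+](=O)[O-])c2)cc(OC)c1OC` — >= 125000 nM
compound 3 `COc1cc(NC(=O)Nc2ccc(F)cc2)cc(OC)c1OC` — 104000 nM

Three compounds of the shared core have been run in a functional assay on Daoy cells (Homo sapiens) for cytotoxicity, read by MTT assay, with a stated time of 72 h; on this read-out lower numbers stand for stronger inhibition and higher numbers for weaker inhibition. For compound 1 the result is a limit of the assay rather than a number, >= 125000 nM. For compound 2 the result is likewise a limit of the assay, >= 125000 nM. Compound 3 gives an actual number, 104000 nM. Compound 2 therefore stands at the limit of >= 125000 nM in this assay, at which 2 of the 3 values shown sit, and has no number of its own to anchor a step.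

Compound 4 `COc1cc(N(C)C(=O)c2cccc([N+](=O)[O-])c2)cc(OC)c1OC` has not yet been measured in this assay. It differs from compound 2 in one place: methyl in place of hydrogen on an amide-type nitrogen. Within the data shown here, no step between two measured compounds exists, so the size of this change cannot be read off from a precedent.

With compound 2 already at a limit, the expected step from compound 2 to compound 4 is a number no higher from compound 2 to compound 4 (the limit leaves the size open), that is none beyond the scatter. Compound 4 is accordingly estimated at 125000 nM, with a range from 60000 nM to 300000 nM, and a fair chance that only a limit is reported again.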

Compound 4, half-maximal inhibitory concentration: >= 125000 nM
Compound 4: a limit, no number; the forecaster's own chance of this, stated with the estimate: 70%; the middle value sits exactly at the limit.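

Compound 2 and compound 4 both give only a limit of the assay, so no step can be read for methyl in place of hydrogen on the amide-type nitrogen: the limit of >= 125000 nM in this assay, at which 3 of the 4 values shown sit.

The compounds shown leave open whether this methyl changes cytotoxicity at all, as neither compound has a number of its own.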